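Series notes: expected activity of unmeasured compound 3

A few compounds are considered here, and "the series" means these few. Any claim that something is new, unique, unknown or untested is made for them only; others in the source may bear on it.

Measured so far:
compound 1, `CC(C(=O)N1CCN(c2cccc(Cl)c2)CC1)N1C(=O)CCC1=O` — in a functional assay on the whole organism (strain Swiss) with Mus musculus as the target, in the maximal electroshock model, with a stated time of 0.25 h, at a dose of 300 mg/kg by the intraperitoneal route (a lower number here means a weaker effect, a higher number a stronger effect of the compound at the dose given), compound 1 gives 75%
compound 2, `CC(C(=O)N1CCN(c2ccccc2F)CC1)N1C(=O)CCC1=O` — in this assay compound 2 gives 100%

Going by the values given here, compound 2 stands highest of the two numbers; the nearest is compound 1, and the single measured step, a number 25 percentage points higher from compound 1 to compound 2 (beyond the scatter), is modest and beyond the scatter. Compound 3, `CC(C(=O)N1CCN(c2ccccc2Cl)CC1)N1C(=O)CCC1=O`, differs from compound 2 by chloro in place of fluoro on an aromatic carbon. Among the compounds with values here, the one measured step bears on this only loosely, as it exchanges both the halogen and the place where it sits, whereas here only the halogen changes at the same place. Within the data shown here, compound 2 already stands at the top of the scale in this assay, so no upward step can appear. Compound 3 is therefore expected to stay close to compound 2, with a number 10 percentage points lower from compound 2 to compound 3 (within the scatter) expected as a step within the scatter. For compound 3 the estimate is 90%, with a range from 70% to 100%.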

Compound 3, a percentage reported as activity, at one dose (the size of the read-out at that dose, not a potency): 0%
For compound 3 the middle estimate is 90 percentage points above the measured one, and the stated range ends above it.
By their numbers in this assay, from the lowest: compound 3; then compound 1; then compound 2.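

In this assay the halogen at this place, on an aromatic carbon ortho to a large group, is not interchangeable: chloro in place of fluoro gives a number 100 percentage points lower from compound 2 to compound 3 (beyond the scatter), so one atom spans the whole read-out between these two compounds. The place of the chloro also counts, as 2-chlorophenyl in place of 3-chlorophenyl gives a number 75 percentage points lower from compound 1 to compound 3 (beyond the scatter); this separates place from halogen, which the earlier step changed together. Nothing available bears on why activity is lost in this change.

The compounds shown leave open whether a plain phenyl, 2-methylphenyl or 2-methoxyphenyl group would read like 2-fluorophenyl or like 2-chlorophenyl, and how 3-fluorophenyl would read. They also leave open whether compound 3 would show activity at another dose or another time.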